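Pyridin-2-yl in Place of Phenyl: Expected Solubility

The compounds below may be only part of what the source reports. "The series", "measured", "known", "first", "only" and "open" are said of these compounds alone.

Among the measured compounds shown here, compound 1 `Cn1cc(C(=O)Nc2ccc(-c3ccccc3)c(C(F)(F)F)c2)c(=O)c2cnccc21` was tested in a physicochemical assay for solubility, in simulated intestinal fluid, at pH 7.4 (a higher number here means a more soluble compound, a lower number a less soluble compound), where compound 1 gives 4.9 ug/mL, the lowest of the three numbers so far. Compound 2 `Cn1cc(C(=O)Nc2ccc(-c3ccccn3)c(C(F)(F)F)c2)c(=O)c2ccccc21` gives 5.2 ug/mL in this assay, within the scatter of compound 1, while compound 3 `Cn1cc(C(=O)Nc2cnc(-c3ccccc3)c(C(F)(F)F)c2)c(=O)c2ccccc21` gives 13 ug/mL, beyond the scatter above compound 1. Compound 4 `Cn1cc(C(=O)Nc2ccc(-c3ccccn3)c(C(F)(F)F)c2)c(=O)c2cnccc21` has not yet been measured. Relative to compound 1 its change is pyridin-2-yl in place of phenyl on an aromatic carbon. For the measured compounds named here, no measured pair shows this change by itself, so its size is open. A small rise, of a size near the edge of the scatter, is expected as the step of a 1.6-fold higher number from compound 1 to compound 4 (0.21 log units; within the scatter). Compound 4 is therefore expected to give 8 ug/mL in this assay, with a range from 3 ug/mL to 20 ug/mL.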

Compound 4, solubility: 6.7 ug/mL
Compound 4: middle estimate off by 1.2-fold (0.08 log units), on the high side; measured number inside the range.
By their numbers in this assay, from the lowest: compounds 1, 2, 4 and 3 (each within the scatter of the next, the first and the last beyond it).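

This first direct reading of the change, in this assay, gives a 1.4-fold higher number from compound 1 to compound 4 (0.14 log units; within the scatter) for pyridin-2-yl in place of phenyl on an aromatic carbon, ortho to a trifluoromethyl group. At this position, on the core of compound 1, the change therefore does not separate the two compounds beyond the usual scatter. No measurement shown bears on the reason for this result.

Among the compounds shown here, only this one pair carries the change, so its size on another core remains open. Also open, on these data alone, is whether a different group here, such as an amine or a carboxylic acid, would give a step beyond the scatter.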